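The source may hold more compounds than are shown below. What is called first, only, known or untested is meant among the compounds shown, and "the series" means these compounds.

In a functional assay on the whole organism (Tail, strain ICR) with Mus musculus as the target, in the tail flick test, with a stated time of 30 min, at a dose of 25 umol/kg by the oral route (a higher number here means a stronger effect of the compound at the dose given, a lower number a weaker effect), the three measured compounds read:

compound 1, `O=C(CN(c1nc(Cl)nc2[nH]cnc12)C1CC1)NCC(=O)OCc1ccccc1`: 18.7%
compound 2, `C[C@@H](O)[C@H](NC(=O)CN(c1nc(Cl)nc2[nH]cnc12)C1CC1)C(=O)OCc1ccccc1`: 21.9%
compound 3, `CC[C@H](C)[C@H](NC(=O)CN(c1ncnc2c1ncn2C1CCCCO1)C1CC1)C(=O)OCc1ccccc1`: 25.6%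

Compound 3 holds the highest of the three numbers, yet its gap to compound 2 and to compound 1 lies within the scatter, so no order among them can be read. Compound 4, `O=C(CN(c1ncnc2c1ncn2C1CCCCO1)C1CC1)N[C@@H](CC(=O)OCc1ccccc1)C(=O)OCc1ccccc1`, has not been measured in this assay. Relative to compound 3 it carries (benzyloxycarbonyl)methyl in place of sec-butyl on a saturated chain carbon bound to an amide-type nitrogen and a carbonyl carbon. Within the data shown here, the only measured step at that same place is a number 3.2 percentage points higher from compound 1 to compound 2 (within the scatter), within the scatter, and it supplies no sign that exchanges there move the read-out. For compound 4 the expected step is therefore a number 1.6 percentage points lower from compound 3 to compound 4 (within the scatter), none beyond the scatter. Compound 4 is estimated at 24%, between 10% and 38%.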

Compound 4, a percentage reported as activity, at one dose (the size of the read-out at that dose, not a potency): 31.8%
For compound 4 the middle estimate is 7.8 percentage points below the measured one; low and high end bracket the measured number.
By their numbers in this assay, from the lowest: compounds 1, 2, 3 and 4 (each within the scatter of the next, the first and the last beyond it).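

In this assay, (benzyloxycarbonyl)methyl in place of sec-butyl gives a number 6.2 percentage points higher from compound 3 to compound 4 (within the scatter), so even an entering group of 11 heavy atoms, with an aromatic ring and 2 hydrogen-bond acceptors, produces no step beyond the scatter. With a number 3.2 percentage points higher from compound 1 to compound 2 (within the scatter), that makes two exchanges at this place, neither beyond the scatter. No available measurement bears on this result.

On these data alone, whether a carboxylic acid or an amine on this chain carbon would give a step beyond the scatter remains open.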